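The source may report more compounds than this note shows. Statements on the series, on what has been measured and on what is new or still open speak of the compounds shown alone.

Compound 2 `CCOC(=O)CCCCCOc1cccc(CN(C(=O)c2ccc(-c3cccc(OC(F)(F)F)c3)cc2)C(C)C)c1` carries a 3-(trifluoromethoxy)phenyl group on an aromatic carbon of the shared core. In an ADME assay on HepG2 cells (Homo sapiens) for cytotoxicity, read by CellTiter-Glo and resazurin assay, with a stated time of 72 h (on this read-out lower numbers stand for an effect already at smaller amounts and higher numbers for an effect only at larger amounts of compound), compound 2 gives only a limit, > 26000 nM, and no number. Compound 1 `CCOC(=O)CCCCCOc1cccc(CN(C(=O)c2ccc(-c3ccc4ccccc4c3)cc2)C(C)C)c1` differs from it in one place, with naphthalen-2-yl where compound 2 has 3-(trifluoromethoxy)phenyl. In this assay compound 1 also gives only a limit, > 26000 nM. Among the compounds with values here, the single measured step, a step that the two limits leave unreadable from compound 1 to compound 2, therefore cannot be read, since both values rest at the limit of > 26000 nM in this assay, at which 2 of the 2 values shown sit. Compound 3 `CCOC(=O)CCCCCOc1cccc(CN(C(=O)c2ccc(-c3cccc(CC(=O)O)c3)cc2)C(C)C)c1` is the compound not yet measured; it differs from compound 2 by carboxymethyl in place of trifluoromethoxy on an aromatic carbon. Within the data shown here, no measured step mirrors this change, and the one step to hand gives no size, so compound 3 is expected to remain at the same limit, a step that the limit leaves unreadable from compound 2 to compound 3. For compound 3 in this assay the estimate is 40000 nM, within a range from 15000 nM to 120000 nM.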

Compound 3, half-maximal effective concentration: > 26000 nM
Compound 3: only a limit was reported (the forecaster's own chance of this, stated with the estimate: 85%); the middle value is on the limit's open side.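

Compound 3 also gives only a limit in this assay, so its steps from compound 1 and compound 2 cannot be read: (the limit of > 26000 nM in this assay, at which 3 of the 3 values shown sit). From the compounds shown here alone, how compound 1, compound 2 and compound 3 compare in this assay, and at what concentration each would show an effect, stays open.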